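The source may hold more compounds than are shown below. What is called first, only, known or untested is meant among the compounds shown, and "the series" means these compounds.

Measured so far:
compound 1 `Cc1n[nH]c(C(=O)O)c1Cc1cccc(-c2ccc(OC(F)(F)F)cc2)c1` — 34%
compound 2 `Cc1n[nH]c(C(=O)O)c1Cc1cccc(-c2ccc(C(F)(F)F)cc2)c1` — 30%
compound 3 `Cc1n[nH]c(C(=O)O)c1Cc1ccc(-c2ccc(C(F)(F)F)cc2)cc1` — 14%

In an assay on isolated protein for inhibition of 2-Hydroxyacid oxidase 2 (Homo sapiens), tested at 10 uM (a higher number here means a stronger effect of the compound at the concentration tested, a lower number a weaker effect), compound 1 gives 34%, compound 2 gives 30% and compound 3 gives 14%. The change from compound 2 to compound 1 is trifluoromethoxy in place of trifluoromethyl on an aromatic carbon; it made a number 4 percentage points higher from compound 2 to compound 1 (within the scatter). Compound 2 and compound 3 are built from the same atoms joined differently; the difference between the two cores is not broken down here, and their values show compound 3 lower than compound 2.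

Compound 4 `Cc1n[nH]c(C(=O)O)c1Cc1ccc(-c2ccc(OC(F)(F)F)cc2)cc1` is not yet measured. It differs from compound 3 by trifluoromethoxy in place of trifluoromethyl on an aromatic carbon, the same change as from compound 2 to compound 1, at the same place. From compound 3 to compound 4 the step expected in this assay is a number 4 percentage points higher from compound 3 to compound 4 (within the scatter), beside the earlier a number 4 percentage points higher from compound 2 to compound 1 (within the scatter); this rests on that one measured pair only. Compound 4 is therefore estimated at 18%, expected between 8% and 28%.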

Compound 4, a percentage reported as inhibition, at one concentration (the size of the read-out at that concentration, not a potency): 29%
Beside the measured number, compound 4's estimate is 11 percentage points below it; the measured number lies above the stated range.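

In this assay, trifluoromethoxy in place of trifluoromethyl gives a number 15 percentage points higher from compound 3 to compound 4 (beyond the scatter). The two steps for this change, one on each core, cannot be told apart: the same change on two cores in this assay, a number 4 percentage points higher (within the scatter) from compound 2 to compound 1 and a number 15 percentage points higher (beyond the scatter) from compound 3 to compound 4, 11 percentage points apart, within the scatter of two such steps. The change can therefore be carried between these two cores without a measurable difference in step size, but with one pair per core this does not prove that the steps are equal, nor does it predict the step on any further core.

The compounds shown leave open how a nitrile, an amine or a longer chain would read at this place on either core. They also leave open whether an amide could stand in place of the carboxylic acid.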